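A few compounds are considered here, and "the series" means these few. Any claim that something is new, unique, unknown or untested is made for them only; others in the source may bear on it.

Measured in a functional assay on CCRF-CEM cells (Homo sapiens) for inhibition, read by sulforhodamine B assay, with a stated time of 48 h; a lower number here means a stronger inhibitor of growth, a higher number a weaker inhibitor of growth:
compound 1 `COc1cc(OC)cc(-c2ccc(-c3ccc(C(=N)N)c(F)c3)s2)c1` gives 306 nM
compound 2 `N=C(N)c1ccc(-c2ccc(-c3ccc(Cl)cc3)s2)cc1F` gives 194 nM
compound 3 `N=C(N)c1ccc(-c2ccc(-c3ccc(Cl)cc3)s2)cc1` gives 200 nM

The three numbers sit within the scatter of one another; no order among compound 1, compound 2 and compound 3 can be read from them. The difference between the core of compound 1 and the core of compound 2 is not broken down here. Compound 2 and compound 3 are related by hydrogen in place of fluoro on an aromatic carbon, and that step gave a 1.0-fold higher number from compound 2 to compound 3 (0.01 log units; within the scatter).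

Compound 4 `COc1cc(OC)cc(-c2ccc(-c3ccc(C(=N)N)cc3)s2)c1` stands to compound 1 as compound 3 stands to compound 2: hydrogen in place of fluoro on an aromatic carbon, the same change at the same kind of place. Compound 4 is expected to move by a 1.0-fold lower number from compound 1 to compound 4 (0.01 log units; within the scatter) in this assay, because the same change gave a 1.0-fold higher number from compound 2 to compound 3 (0.01 log units; within the scatter). Compound 4 is thus estimated at 300 nM, with a range from 150 nM to 600 nM.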

Compound 4, concentration for 50% growth inhibition: 1880 nM
Estimate against measurement, compound 4: 6.3-fold (0.80 log units) below; measured number above the stated range.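

Hydrogen in place of fluoro on an aromatic carbon gave a 6.1-fold higher number from compound 1 to compound 4 (0.79 log units; beyond the scatter) in this assay, so the step on the core of compound 1 is not the step seen on the core of compound 2. The size of this change therefore did not carry from one core to the other: the same change on two cores in this assay, a 1.0-fold higher number (0.01 log units; within the scatter) from compound 2 to compound 3 and a 6.1-fold higher number (0.79 log units; beyond the scatter) from compound 1 to compound 4, 6.0-fold (0.78 log units) apart, beyond the scatter of two such steps This shows that, across these two pairs, the step depends on the core; it does not show which feature of the core is responsible, and two pairs set no general rule for the series.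

Which part of the difference between the two cores goes with the gap between the steps remains open. Also open, going by these compounds, is how a hydroxyl or a nitrile in place of the fluoro would behave on either core.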